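One aryl swap, repeated on a rearranged core

This account rests on a few compounds, and the source may have more. Where it says the series, first, only, none or still open, it means among the compounds named here.

Four related compounds are compared in a functional assay on MDA-MB-231 cells (Homo sapiens) for antiproliferative activity, read by MTT assay, with a stated time of 24 h; on this read-out higher numbers stand for weaker inhibition and lower numbers for stronger inhibition. Compound 1 `Cc1cccc(NNC(=O)c2ccc(NS(=O)(=O)c3cnc(O)nc3O)cc2)c1` gives only a limit in this assay, > 20000 nM. Its partner compound 2 `O=C(NNc1ccccc1Cl)c1ccc(NS(=O)(=O)c2cnc(O)nc2O)cc1` gives 4010 nM in this assay. The change from compound 1 to compound 2 is 2-chlorophenyl in place of 3-methylphenyl on an amine nitrogen, and it produced an at least 4.9-fold lower number from compound 1 to compound 2 (0.69 log units; beyond the scatter). Compound 3 `Cc1cccc(NNC(=O)c2cccc(NS(=O)(=O)c3cnc(O)nc3O)c2)c1` has the same atoms as compound 1 joined differently; the difference between the two cores is not broken down here. Compound 3 also gives only a limit in this assay, > 20000 nM. Two of the three measured values thus sit at the limit of > 20000 nM in this assay, at which 2 of the 3 values shown sit, so the size of the first step is known only as a lower bound. Compound 4 `O=C(NNc1ccccc1Cl)c1cccc(NS(=O)(=O)c2cnc(O)nc2O)c1` is not yet measured; it differs from compound 3 by 2-chlorophenyl in place of 3-methylphenyl on an amine nitrogen, the same change at the same place as in the first pair. That change gave an at least 4.9-fold lower number from compound 1 to compound 2 (0.69 log units; beyond the scatter). Compound 4 is therefore expected to show a step of the same kind, an at least 2.5-fold lower number from compound 3 to compound 4 (0.39 log units; beyond the scatter), though on the core of compound 3 its true size is uncertain. Compound 4 is estimated at 8000 nM, with a likely range from 2500 nM to 20000 nM.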

Compound 4, half-maximal inhibitory concentration: 2090 nM
The estimate for compound 4 lay 3.8-fold (0.58 log units) above the measured number; the whole stated range lies above it.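

In this assay, putting 2-chlorophenyl in place of 3-methylphenyl on the amine nitrogen of the second core again gives a clear drop, an at least 9.5-fold lower number from compound 3 to compound 4 (0.98 log units; beyond the scatter). The change therefore points the same way on both cores, and this is the part that carries over: the same change on two cores in this assay, an at least 4.9-fold lower number (0.69 log units; beyond the scatter) from compound 1 to compound 2 and an at least 9.5-fold lower number (0.98 log units; beyond the scatter) from compound 3 to compound 4; the limit leaves it open whether they differ. Each step starts from a compound that gives only a limit, so both sizes are lower bounds, and the two pairs show a shared direction but not a shared size, nor that the change would act the same way on any other core: the limit of > 20000 nM in this assay, at which 2 of the 4 values shown sit.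

The compounds shown leave open whether the drop comes from gaining the chlorine or from losing the methyl, since the two changes always occur together here. A plain phenyl group on the same nitrogen, or a bromophenyl or methoxyphenyl group, would be needed on both cores to separate these possibilities.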